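This account rests on a few compounds, and the source may have more. Where it says the series, first, only, none or still open, it means among the compounds named here.

Compound 1 `CC(C)(C)NC(=O)CCc1cccc2c1B(O)OC2` carries a tert-butyl group on its amide nitrogen. In a functional assay on SK-OV-3 cells (Homo sapiens) for antiproliferative activity, read by MTT assay, with a stated time of 72 h (on this read-out higher numbers stand for weaker inhibition and lower numbers for stronger inhibition), compound 1 gives > 100000 nM, which is a limit of the assay rather than a measured number. Compound 1 thus sits at the limit of > 100000 nM in this assay, at which 1 of the 2 values shown sits. Compound 2 `COc1ccc(NC(=O)CCc2cccc3c2B(O)OC3)cc1` carries a 4-methoxyphenyl group in the same position, and in this assay compound 2 gives 900 nM. Compound 3 `O=C(CCc1cccc2c1B(O)OC2)Nc1cccc(I)c1` has not yet been measured. The change from compound 1 to compound 3 is 3-iodophenyl in place of tert-butyl on an amide-type nitrogen. Within the data shown here, no two measured compounds differ in only one place, so no single step can be read straight from the numbers. What the numbers do show is that compound 2, with a phenyl-type group on the amide nitrogen, reaches a measurable value, whereas compound 1 with tert-butyl does not. Compound 3 likewise carries a phenyl-type group, so a large step towards stronger inhibition is expected, an at least 83-fold lower number from compound 1 to compound 3 (1.92 log units; beyond the scatter). Compound 3 is therefore expected to give about 1200 nM, between 250 nM and 6000 nM.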

Compound 3, half-maximal inhibitory concentration: 630 nM
Compound 3: the middle estimate sits 1.9-fold (0.28 log units) above what was measured, and the stated range covers the measured number.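

Among these compounds, this is the first step at this position that can be read directly: in this assay, putting 3-iodophenyl in place of tert-butyl on the amide-type nitrogen, with the rest of the molecule unchanged, gives an at least 150-fold lower number from compound 1 to compound 3 (2.20 log units; beyond the scatter). The group on this nitrogen can therefore move the read-out by a large amount, and the 4-methoxyphenyl of compound 2 and the 3-iodophenyl of compound 3 both give measured numbers. The true size of the step remains unknown, since it starts from a limit of the assay: the limit of > 100000 nM in this assay, at which 1 of the 3 values shown sits.

The compounds shown cannot separate the contribution of the aromatic ring from that of the iodine or of its place on the ring. They also leave open what an unsubstituted phenyl, a benzyl group or a longer alkyl chain would give on this nitrogen.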